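Two Chlorines Exchanged for Two Fluorines

The source may hold more compounds than are shown below. What is called first, only, known or untested is meant among the compounds shown, and "the series" means these compounds.

Three compounds have numbers in a functional assay on NCI-H23 cells (Homo sapiens) for cytotoxicity, read by sulforhodamine B assay, with a stated time of 48 h, tested at 1 uM; a lower number here means a stronger effect, a higher number a weaker effect of the compound at the concentration tested:

compound 1 `COc1ccc(-c2cc(/C=C/C(=O)c3ccc(N)cc3)[nH]n2)cc1`: 93%
compound 2 `COc1cc(-c2cc(/C=C/C(=O)c3ccc(N)cc3)[nH]n2)cc(OC)c1OC`: 95%
compound 3 `COc1cc(-c2cc(/C=C/C(=O)c3ccc(Cl)c(Cl)c3)[nH]n2)cc(OC)c1OC`: 95%

Compound 3 stands level with compound 2, the two of them together holding the highest numbers of the three. Its nearest neighbour is compound 2, with no change within the scatter; its furthest is compound 1, whose number is slightly lower but still within the scatter, so no order among the three can be claimed.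

Compound 4 `COc1cc(-c2cc(/C=C/C(=O)c3ccc(F)c(F)c3)[nH]n2)cc(OC)c1OC` differs from compound 3 in one place: 3,4-difluorophenyl in place of 3,4-dichlorophenyl on a carbonyl carbon.

Going by the values given here, one measured step bears on this position. Going no change at the digits printed from compound 2 to compound 3 (within the scatter) exchanged the whole group on the carbonyl carbon, a larger change than the one now at hand, and the number did not move beyond the scatter. Among the compounds with values here, with compound 1, compound 2 and compound 3 all sitting near the same high level, and no measured step at this position producing a shift, the expectation for compound 4 is no step beyond the scatter, which is what a number 1 percentage points lower from compound 3 to compound 4 (within the scatter) expresses.

Compound 4 is therefore estimated at 94% in this assay, with a range from 84% to 100%.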

Compound 4, a percentage reported as activity, at one concentration (the size of the read-out at that concentration, not a potency): 90%
Compound 4: middle estimate off by 4 percentage points, on the high side, and the stated range covers the measured number.
By their numbers in this assay, from the lowest: compounds 4, 1, 2 and 3 (each within the scatter of the next).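

In this assay, going by these compounds alone, the exchange of the two chlorines for two fluorines on the phenyl group held by the carbonyl carbon gives a number 5 percentage points lower from compound 3 to compound 4 (within the scatter), so the change of halogen itself, which the earlier compounds did not address, leaves no reading beyond the scatter. Set against the 4-aminophenyl group, the 3,4-difluorophenyl group gives a number 5 percentage points lower from compound 2 to compound 4 (within the scatter), which means that three different groups at this place, on an otherwise identical molecule, now lie within the scatter of one another, where the earlier compounds offered only two. The data hold no measurement that would explain this lack of response at the position.

All of these numbers come from a single concentration, so they cannot tell whether the three groups would separate at a higher one, where an effect on the cells might become visible. Also open, as far as these compounds go, is whether a group of a different kind on the carbonyl carbon, such as a carboxylic acid, a morpholine ring or a longer alkyl chain, would move the number beyond the scatter.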